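Moving a methoxy group on a benzoyl arm

The compounds below may be only part of what the source reports. "The series", "measured", "known", "first", "only" and "open" are said of these compounds alone.

Three compounds share a bicyclic core carrying an amide on one side and an aromatic ring on the other. Compound 1 is `COc1cc(OC)nc(N2C[C@H]3CN(C(=O)c4ccccc4-c4cccs4)C[C@H]3C2)n1`, compound 2 is `COc1cccc(OC)c1C(=O)N1C[C@@H]2CN(c3nc4ccc(Cl)cc4s3)C[C@@H]2C1` and compound 3 is `Cc1cc(C)nc(N2C[C@H]3CN(C(=O)c4ccccc4-c4cccc(F)c4)C[C@H]3C2)n1`. In an assay on isolated protein for binding affinity to Orexin receptor type 2 (Homo sapiens) (on this read-out higher numbers stand for weaker inhibition and lower numbers for stronger inhibition), compound 1 gives 41 nM, compound 2 gives 2200 nM and compound 3 gives 180 nM. Compound 2 therefore stands with the highest number of the three, which on this read-out means the weakest binding; its gap to compound 3 and its gap to compound 1 both lie beyond the usual scatter.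

Compound 4 is `COc1ccc(C(=O)N2C[C@@H]3CN(c4nc5ccc(Cl)cc5s4)C[C@@H]3C2)c(OC)c1`, not yet measured. It differs from compound 2 in one place: 2,4-dimethoxyphenyl in place of 2,6-dimethoxyphenyl on a carbonyl carbon. The same atoms are present, but one methoxy group sits at a different spot on the aromatic ring attached to the carbonyl carbon.

For the measured compounds named here, no pair among the measured compounds shows what such a move does on this scaffold, so the direction cannot be read from the data. The expectation is a step from compound 2 to compound 4 of a 1.1-fold higher number from compound 2 to compound 4 (0.06 log units; within the scatter), which is not clearly beyond the scatter in either direction. Compound 4 is estimated at 2500 nM in this assay, within a range of 700 nM to 9000 nM.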

Compound 4, inhibition constant: 510 nM
The estimate for compound 4 lay 4.9-fold (0.69 log units) above the measured number; the whole stated range lies above it.
By their numbers in this assay, from the lowest: compound 1; then compound 3; then compound 4; then compound 2.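

In this assay, replacing 2,6-dimethoxyphenyl with 2,4-dimethoxyphenyl on the carbonyl carbon gives a 4.3-fold lower number from compound 2 to compound 4 (0.63 log units; beyond the scatter). For the compounds shown here, the atoms stay the same, so where one methoxy group sits on this ring is enough to change the binding by more than the usual scatter, and here the 2,4-dimethoxyphenyl arrangement binds more strongly; the earlier compounds could not show this, as no two of them differed in only one place. Nothing in the available data explains the change.

This single step cannot tell whether the gain comes from the methoxy group leaving its old spot or from its arrival at the new one, and a comparison with an unsubstituted phenyl ring, or with an ethoxy group in place of a methoxy group, would be needed to begin separating such possibilities. Going by these compounds alone, it also remains open whether the same move would have a similar effect on a compound with a different group on the other side of the shared core, as this pair gives only one example.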